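Benzylselanyl for methylsulfanyl on a bis-acyl isothiourea core

This account rests on a few compounds, and the source may have more. Where it says the series, first, only, none or still open, it means among the compounds named here.

Compound 1 `CS/C(=N\C(=O)c1csc([N+](=O)[O-])c1)NC(=O)c1csc([N+](=O)[O-])c1`: in a functional assay on MCF7 cells (Homo sapiens) for cytotoxicity, read by MTT assay, with a stated time of 72 h (a lower number here means that less compound is tolerated, a higher number that more compound is tolerated), compound 1 reaches only the assay limit, > 100000 nM.
Compound 2 `CS/C(=N\C(=O)c1cc2ccccc2s1)NC(=O)c1cc2ccccc2s1`: in this assay compound 2 gives 78500 nM.
Compound 3 `CS/C(=N\C(=O)c1cccs1)NC(=O)c1cccs1`: in this assay compound 3 reaches only the assay limit, > 100000 nM.

Compound 1 therefore stands at the top of the measurable range, and it is not alone there: two of the three values sit at this limit (the limit of > 100000 nM in this assay, at which 2 of the 3 values shown sit). Only compound 2 returns a number, and that number lies not far below the limit itself. Going by the values given here, none of the three measured compounds differs from another in a single place, so no measured step is available to guide an expectation for the new compound.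

Compound 4 `O=C(/N=C(/NC(=O)c1csc([N+](=O)[O-])c1)[Se]Cc1ccccc1)c1csc([N+](=O)[O-])c1` keeps the core of compound 1 and changes it in one place: a group of 8 heavy atoms (7 carbon, 1 selenium; one six-membered aromatic ring of carbon only) in place of a group of 2 heavy atoms (1 carbon, 1 sulfur; no ring), on a carbon with a double bond to nitrogen. With every measured value either at the limit or close to it, there is no sign in these data that a change of this kind moves the read-out by more than the usual scatter. The step from an at least 1.2-fold lower number from compound 1 to compound 4 (0.09 log units; that floor lies within the scatter) is therefore expected to be small, with no direction that can be asserted beyond the scatter. In this assay compound 4 is expected to give about 80000 nM, within a range from 30000 nM to 200000 nM, with a real chance that only a limit is reported again.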

Compound 4, concentration lethal to 50% of the cells: 83800 nM
Beside the measured number, compound 4's estimate is 1.0-fold (0.02 log units) below it, within the range that was stated.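

Exchanging methylsulfanyl for the group of 8 heavy atoms, on a carbon with a double bond to nitrogen, gives in this assay an at least 1.1-fold lower number from compound 1 to compound 4 (0.07 log units; that floor lies within the scatter). Going by these compounds alone, this is the first comparison here between compounds that differ in one place, and it shows that this carbon can carry a group holding selenium and a six-membered aromatic ring while the read-out of compound 4 remains a number rather than a limit, with no change beyond the scatter that can be read from the step. Only a floor can be given for this step, as the value at its compound 1 end is a limit of the assay and not a number: the limit of > 100000 nM in this assay, at which 2 of the 4 values shown sit.

From the compounds shown here alone, whether the selenium atom or the aromatic ring matters for the read-out of compound 4 remains open, and a methylselanyl or a benzylsulfanyl group on this carbon would separate the two. Also open, going by these compounds, is whether an amine or a longer alkyl chain at this place would give a number well under the limit, and whether the same exchange would read alike on compound 2 or compound 3.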